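Removing One Hydroxy From Compound 3

This account rests on a few compounds, and the source may have more. Where it says the series, first, only, none or still open, it means among the compounds named here.

Compound 1 `CC(C)NC(=N)c1ccc(-c2cc3cc(C(=N)NC(C)C)ccc3o2)cc1`, compound 2 `CC(C)NC(=N)c1ccc(-c2cc3cc(C(=N)NC(C)C)cc(O)c3o2)cc1` and compound 3 `CC(C)NC(=N)c1ccc(-c2cc3cc(C(=N)NC(C)C)cc(O)c3o2)c(O)c1` share one core and differ only in their hydroxy groups. In an ADME assay on L6 cells (Rattus norvegicus) for cytotoxicity (on this read-out lower numbers stand for stronger inhibition and higher numbers for weaker inhibition), compound 1 gives > 198000 nM, which is a limit. Compound 2 gives > 185000 nM, also a limit. Compound 3 gives > 179000 nM, again a limit, so no exact number is known for it.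

Compound 4 `CC(C)NC(=N)c1ccc(-c2cc3cc(C(=N)NC(C)C)ccc3o2)c(O)c1` has not yet been measured. It differs from compound 3 by hydrogen in place of hydroxy on an aromatic carbon, which is hydrogen in place of hydroxy on an aromatic carbon. Within the data shown here, two measured steps bear on this, each with hydroxy in place of hydrogen on an aromatic carbon: a step that the two limits leave unreadable from compound 1 to compound 2, and a step that the two limits leave unreadable from compound 2 to compound 3. Neither has a readable size, so there is no measured shift to carry over, and no change beyond the scatter is expected in this assay. The expected size is a step that the limit leaves unreadable from compound 3 to compound 4. For compound 4 the estimate is 190000 nM, with an expected range of 90000 nM to 260000 nM.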

Compound 4, half-maximal inhibitory concentration: > 183000 nM
Compound 4 gave a limit, no number (the forecaster's own chance of this, stated with the estimate: 85%); the middle value does not contradict the limit.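

Compound 4 also gives only a limit, so neither the step from compound 3 to compound 4 nor the step from compound 1 to compound 4 can be read. From the compounds shown here alone, with only limits for all four compounds, it remains open whether hydroxy in place of hydrogen on an aromatic carbon changes the result in this assay at all.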